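Benzotriazole series: aryl swap on the pyridine carbon

The compounds below may be only part of what the source reports. "The series", "measured", "known", "first", "only" and "open" are said of these compounds alone.

Measured so far:
- Compound 1 `Fc1cc(Cl)ccc1-c1ccc(Cn2nnc3ccccc32)cn1`: 0.8 mL/min/g
- Compound 2 `Fc1ccccc1-c1ccc(Cn2nnc3ccccc32)cn1`: "not determined" (no result reported)

In an ADME assay on microsomes from liver (Rattus norvegicus, strain Wistar) for metabolic stability, tested at 2.5 uM (on this read-out lower numbers stand for slow clearance and higher numbers for fast clearance), compound 1 gives 0.8 mL/min/g, whereas compound 2 gives "not determined" (no result reported), so compound 2 has no number to stand on. Compound 3 `Clc1ccc(-c2ccc(Cn3nnc4ccccc43)cn2)cc1` follows from compound 2 by 4-chlorophenyl in place of 2-fluorophenyl on an aromatic carbon. For the measured compounds named here, with no measured step from compound 2, the expectation for compound 3 rests on compound 1, which gives 0.8 mL/min/g in this assay and carries the same 4-chlorophenyl. In this assay any step from compound 2 to compound 3 is expected to stay within the scatter, in no clear direction. Compound 3 is estimated at 1 mL/min/g, within 0.4 mL/min/g to 2.5 mL/min/g.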

Compound 3, intrinsic clearance in a liver preparation (reported as CLH), per the amount of preparation that the assay uses: 1 mL/min/g
The estimate for compound 3 equals the measured number at the digits printed; the measured number falls inside the stated range.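

In this assay, hydrogen in place of fluoro on an aromatic carbon, with the 4-chlorophenyl kept, gives a 1.3-fold higher number from compound 1 to compound 3 (0.10 log units; within the scatter), so in this pair the fluoro leaves the clearance number unchanged beyond repeat noise. The direct swap of 2-fluorophenyl for 4-chlorophenyl cannot be read, as compound 2 has no number. No measurement on hand accounts for this result. Open: whether an amine or a carboxylic acid in place of the chloro on the phenyl ring would take the number in this assay beyond the scatter.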